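The source may hold more compounds than are shown below. What is called first, only, known or untested is meant among the compounds shown, and "the series" means these compounds.

Compound 3 `CCCC(=O)Nc1cc(Oc2ccc(Nc3nccc4[nH]cc(-c5ccc(F)cc5)c(=O)c34)cc2F)ccn1` stands lowest of the three measured compounds in a functional assay on MKN-45 cells (Homo sapiens) for antiproliferative activity, read by MTT assay, with a stated time of 72 h, tested at 10 uM; a lower number here means less inhibition, a higher number more inhibition at the concentration tested (going by the name of the read-out): compound 3 gives 64.6%. The two other measured compounds sit above it: compound 1 `CC(=O)Nc1cc(Oc2ccc(Nc3nccc4[nH]cc(-c5ccc(F)cc5)c(=O)c34)cc2F)ccn1` gives 77.1% and compound 2 `CCC(=O)Nc1cc(Oc2ccc(Nc3nccc4[nH]cc(-c5ccc(F)cc5)c(=O)c34)cc2F)ccn1` gives 92.1%, the steps being a number 12.5 percentage points lower from compound 1 to compound 3 (beyond the scatter) and a number 27.5 percentage points lower from compound 2 to compound 3 (beyond the scatter), with a number 15 percentage points higher from compound 1 to compound 2 (beyond the scatter) between the two higher ones. Compound 4 `CC(C)(C)C(=O)Nc1cc(Oc2ccc(Nc3nccc4[nH]cc(-c5ccc(F)cc5)c(=O)c34)cc2F)ccn1` differs from compound 3 by tert-butyl in place of propyl on a carbonyl carbon. The three measured steps all alter the chain on the carbonyl carbon and move this assay modestly, up or down, with no steady direction, so a branched chain of the given size may land anywhere in that spread. Compound 4 is therefore expected to show a number 1.4 percentage points higher from compound 3 to compound 4 (within the scatter) and to give about 66%, with a range from 42% to 88%.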

Compound 4, a percentage reported as inhibition, at one concentration (the size of the read-out at that concentration, not a potency): 62.5%
The estimate for compound 4 lay 3.5 percentage points above the measured number, and the stated range covers the measured number.
By their numbers in this assay, from the lowest: compounds 4 and 3 (each within the scatter of the next); then compound 1; then compound 2.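

Branching does not separate the chain on the carbonyl carbon from its straight counterpart in this assay (tert-butyl in place of propyl: a number 2.1 percentage points lower from compound 3 to compound 4 (within the scatter)). The new compound also falls short of both smaller chains (a number 29.6 percentage points lower from compound 2 to compound 4 (beyond the scatter); a number 14.6 percentage points lower from compound 1 to compound 4 (beyond the scatter)). Among these four compounds, then, propyl and tert-butyl both sit under methyl and ethyl, whether the chain is straight or branched. Nothing available explains this result.

Going by these compounds, whether a longer chain such as butyl, a cyclopropyl ring or a chain carrying an amine would match compound 2 stays open.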